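Catechol vinyl sulfone and sulfoxide series: nitrite inhibition notes

The source may hold more compounds than are shown below. What is called first, only, known or untested is meant among the compounds shown, and "the series" means these compounds.

Measured so far:
Compound 1, `O=S(=O)(/C=C/c1ccc(O)c(O)c1)CCCc1ccccc1`, gives 10500 nM.
Compound 2, `O=S(=O)(/C=C/c1ccc(O)c(O)c1)CCCCc1ccccc1`, gives 19800 nM.
Compound 3, `[O-][S+](/C=C/c1ccc(O)c(O)c1)CCCc1ccccc1`, gives 28600 nM.

All three were read in a functional assay on BV-2 cells (Mus musculus) for inhibition, read by Griess assay, with stated times of 3 h and 24 h; a lower number here means a stronger inhibitor, a higher number a weaker inhibitor. Among the measured compounds shown here, compound 1 and compound 2 share one core; the single change is benzyl in place of phenyl on a saturated chain carbon, three bonds along the chain from a sulfonyl sulfur. That change gave a 1.9-fold higher number from compound 1 to compound 2 (0.28 log units; within the scatter). Compound 3 carries a different core; the difference between the two cores is not broken down here. Compared with compound 1, compound 3 gives a higher number, while compound 3 and compound 2 lie within the scatter of one another.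

Compound 4, `[O-][S+](/C=C/c1ccc(O)c(O)c1)CCCCc1ccccc1`, has not yet been measured in this assay. It differs from compound 3 by benzyl in place of phenyl on a saturated chain carbon, three bonds along the chain from a sulfur. The place is described as three bonds along the chain from a sulfur, where in the earlier pair it was from a sulfonyl sulfur, so this is the same kind of change rather than the same one.

The expected step from compound 3 to compound 4 in this assay is a 1.6-fold higher number from compound 3 to compound 4 (0.20 log units; within the scatter), set beside a 1.9-fold higher number from compound 1 to compound 2 (0.28 log units; within the scatter) and resting on that pair alone. Compound 4 is therefore estimated at 45000 nM, expected between 18000 nM and 110000 nM.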

Compound 4, half-maximal inhibitory concentration: 36800 nM
For compound 4 the middle estimate is 1.2-fold (0.09 log units) above the measured one, within the range that was stated.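

In this assay, benzyl in place of phenyl on the core of compound 3 gives a 1.3-fold higher number from compound 3 to compound 4 (0.11 log units; within the scatter), a step that cannot be told apart from repeat-measurement noise. The same change on the core of compound 1 and on the core of compound 3 shows no difference that can be resolved between the two cores: the same change on two cores in this assay, a 1.9-fold higher number (0.28 log units; within the scatter) from compound 1 to compound 2 and a 1.3-fold higher number (0.11 log units; within the scatter) from compound 3 to compound 4, 1.5-fold (0.17 log units) apart, within the scatter of two such steps. Among the compounds shown here, this agreement shows only that the change stays within the scatter on both cores; with neither step beyond the scatter and a single pair per core, it does not establish that the change has a real effect on either core, nor does it predict the outcome on any other core.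

The compounds shown leave open whether a longer chain would give a step beyond the scatter on either core. Also open, from the compounds shown here alone, is what an amine or a carboxylic acid in place of the phenyl would do in this assay.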